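Dropping the Methoxy Group: What to Expect for Compound 4

The compounds below may be only part of what the source reports. "The series", "measured", "known", "first", "only" and "open" are said of these compounds alone.

Three compounds share one core. Compound 1 `CCC(C)=C1C(=O)N(c2ccc(Cl)cc2)N(c2ccc(Cl)cc2)C1=O`, compound 2 `COc1cc(C=C2C(=O)N(c3ccc(Cl)cc3)N(c3ccc(Cl)cc3)C2=O)ccc1O` and compound 3 `COc1cccc(C=C2C(=O)N(c3ccc(Cl)cc3)N(c3ccc(Cl)cc3)C2=O)c1` were tested in a functional assay on SMMC-7721 cells (Homo sapiens) for cytotoxicity, read by MTT assay, with a stated time of 72 h; a higher number here means a weaker inhibitor, a lower number a stronger inhibitor. Compound 1 gives 49200 nM, compound 2 gives 64900 nM, and compound 3 gives 30200 nM, the lowest of the three numbers, though its gap to compound 1 lies within the scatter. Within the data shown here, the only measured step, a 2.1-fold lower number from compound 2 to compound 3 (0.33 log units; beyond the scatter), concerns a hydroxy group. Compound 4 `O=C1C(=Cc2ccccc2)C(=O)N(c2ccc(Cl)cc2)N1c1ccc(Cl)cc1` differs from compound 3 by hydrogen in place of methoxy on an aromatic carbon. Among the measured compounds shown here, no measured step removes a methoxy group, so the hydroxy step is only a loose guide. The estimated step, a 1.2-fold higher number from compound 3 to compound 4 (0.06 log units; within the scatter), is therefore expected to stay small. Compound 4 is expected to give about 35000 nM, within 15000 nM to 80000 nM.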

Compound 4, half-maximal inhibitory concentration: 26200 nM
For compound 4 the middle estimate is 1.3-fold (0.13 log units) above the measured one; the measured number falls inside the stated range.
By their numbers in this assay, from the lowest: compounds 4, 3, 1 and 2 (each within the scatter of the next, the first and the last beyond it).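

With a 1.2-fold lower number from compound 3 to compound 4 (0.06 log units; within the scatter), the methoxy group can leave this place on the ring without a shift beyond the scatter, so a plain phenyl serves as well as 3-methoxyphenyl. The wider change, a 2.5-fold lower number from compound 2 to compound 4 (0.39 log units; beyond the scatter), shows that 4-hydroxy-3-methoxyphenyl offers no gain over phenyl here. Nothing available explains either step. Still open, on these data alone, is whether a different group at this place, such as an amine or a carboxylic acid, would shift the number beyond the scatter. Also open, as far as these compounds go, is how a 4-hydroxyphenyl group, without methoxy, would compare.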